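A few compounds are considered here, and "the series" means these few. Any claim that something is new, unique, unknown or untested is made for them only; others in the source may bear on it.

Three compounds have so far been measured in a functional assay on MT4 cells (Homo sapiens) for cytotoxicity; a higher number here means that more compound is tolerated, a lower number that less compound is tolerated:

Compound 1 `COC(=O)N[C@H](C(=O)NN(Cc1cccc(-c2ccccc2)c1)C[C@@](O)(Cc1ccccc1)C(=O)N[C@H]1c2ccccc2C[C@H]1O)C(C)(C)C`, which gives > 10000 nM in this assay.
Compound 2 `COC(=O)N[C@H](C(=O)NN(Cc1cccc(-c2ccccn2)c1)C[C@@](O)(Cc1ccccc1)C(=O)N[C@H]1c2ccccc2C[C@H]1O)C(C)(C)C`, which gives 4400 nM.
Compound 3 `COC(=O)N[C@H](C(=O)NN(Cc1cccc(-c2cccnc2)c1)C[C@@](O)(Cc1ccccc1)C(=O)N[C@H]1c2ccccc2C[C@H]1O)C(C)(C)C`, which gives 6800 nM.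

The value for compound 1 is a limit of the assay rather than a number (the limit of > 10000 nM in this assay, at which 1 of the 3 values shown sits). Among the two real numbers, compound 3 stands highest, with compound 2 nearest to it; the step of a 1.5-fold higher number from compound 2 to compound 3 (0.19 log units; within the scatter), so the two cannot be ordered with confidence.

Compound 4 `COC(=O)N[C@H](C(=O)NN(Cc1cccc(/C=C/c2ccccc2)c1)C[C@@](O)(Cc1ccccc1)C(=O)N[C@H]1c2ccccc2C[C@H]1O)C(C)(C)C` differs from compound 3 in one place: 2-phenylethenyl in place of pyridin-3-yl on an aromatic carbon. The measured steps that bear on this are those where a ring nitrogen was introduced into the phenyl of compound 1: an at least 2.2-fold lower number from compound 1 to compound 2 (0.35 log units; beyond the scatter), and an at least 1.4-fold lower number from compound 1 to compound 3 (0.16 log units; that floor lies within the scatter). The change to compound 4 runs the other way, taking the nitrogen out again and extending the group by a double bond, so a number about as high as that of compound 3, or higher, up to the limit seen for compound 1, is expected.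

For compound 4 the estimate is 9000 nM, with a range from 4000 nM to 20000 nM. This corresponds to an expected step of a 1.3-fold higher number from compound 3 to compound 4 (0.12 log units; within the scatter).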

Compound 4, half-maximal cytotoxic concentration: > 10000 nM
Compound 4 was reported as a limit; the forecaster's own chance of this, stated with the estimate: 45%; middle value at least 1.1-fold (0.04 log units) from the limit.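

In this assay compound 4 gives > 10000 nM, which is a limit of the assay and not a number. Replacing a pyridine ring with 2-phenylethenyl at this position, meta to a large group, gives a change that stands out from the scatter when the starting point is pyridin-2-yl, with an at least 2.2-fold higher number from compound 2 to compound 4 (0.35 log units; beyond the scatter), but not yet when it is pyridin-3-yl, with an at least 1.4-fold higher number from compound 3 to compound 4 (0.16 log units; that floor lies within the scatter), where only a floor can be read. The two groups with rings of carbon only, phenyl and 2-phenylethenyl, now both end at the top of the measurable range, so the step between compound 1 and compound 4 cannot be read, and the compounds shown cannot say whether the longer group changes tolerance at all: the limit of > 10000 nM in this assay, at which 2 of the 4 values shown sit.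

Still open, from the compounds shown here alone, is whether a ring nitrogen would lower the number with the double bond in place, as a 2-(pyridin-3-yl)ethenyl group would show. It is also unknown whether the double bond itself matters, which a saturated 2-phenylethyl chain would test.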